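A few compounds are considered here, and "the series" means these few. Any claim that something is new, unique, unknown or untested is made for them only; others in the source may bear on it.

Measured so far:
compound 1 `O=c1[nH]cnc2c1c(-c1ccccc1)cn2-c1ccc(S(=O)(=O)Nc2ccccn2)cc1` — 4670 nM
compound 2 `Nc1ncnc2c1c(-c1ccccc1)cn2-c1ccc(S(=O)(=O)Nc2nccs2)cc1` — 4240 nM

In a functional assay on HepG2 cells (Homo sapiens) for inhibition, read by sulforhodamine B assay, with a stated time of 24 h (a lower number here means a stronger inhibitor, a higher number a weaker inhibitor), compound 2 gives 4240 nM, the lowest of the two numbers; compound 1 sits within the scatter of it, so no order between them is claimed. Compound 3 `Nc1ncnc2c1c(-c1ccccc1)cn2-c1ccc(S(=O)(=O)Nc2ccccn2)cc1` is not yet measured. It differs from compound 2 in one place: pyridin-2-yl in place of 1,3-thiazol-2-yl on a sulfonamide nitrogen. For the measured compounds named here, no measured pair shows this change alone, so there is no step to lean on. Compound 3 is expected to lie close to compound 2, with a step of a 1.1-fold higher number from compound 2 to compound 3 (0.03 log units; within the scatter) that is not expected to exceed the scatter. The estimate for compound 3 in this assay is 4500 nM, with a range from 2000 nM to 10000 nM.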

Compound 3, half-maximal inhibitory concentration: 4090 nM
Compound 3: middle estimate off by 1.1-fold (0.04 log units), on the high side; the measured number falls inside the stated range.
By their numbers in this assay, from the lowest: compounds 3, 2 and 1 (each within the scatter of the next).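

In this assay, for the compounds shown here, pyridin-2-yl in place of 1,3-thiazol-2-yl on a sulfonamide nitrogen gives a 1.0-fold lower number from compound 2 to compound 3 (0.02 log units; within the scatter), the first direct reading of this change on the shared core. On this read-out, the six-membered aromatic ring and the five-membered aromatic ring are not told apart at this position. No measurement bearing on the reason for this result is available. Still open, as far as these compounds go, is whether a methyl or cyclohexyl group on that sulfonamide nitrogen would move the number beyond the scatter.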